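What the Bare Pyrazole Thiol Amide Might Give

A few compounds are considered here, and "the series" means these few. Any claim that something is new, unique, unknown or untested is made for them only; others in the source may bear on it.

Compound 2 `O=C(NCCCCCCS)c1cc(-c2cnccn2)n[nH]1` gives 22 nM in an assay on isolated protein for inhibition of protein deacetylase HDAC6 (Homo sapiens), read by fluorescence, with stated times of 15 min and 60 min (on this read-out lower numbers stand for stronger inhibition and higher numbers for weaker inhibition), the lowest of the two numbers recorded so far. Among the measured compounds shown here, its only measured neighbour is compound 1 `O=C(NCCCCCCS)c1cc(C2CCCCC2)n[nH]1`, which in this assay gives 241 nM. For the measured compounds named here, the step of an 11-fold lower number from compound 1 to compound 2 (1.04 log units; beyond the scatter) is the one comparison available, and it shows that the group on this aromatic carbon moves the read-out strongly. Compound 3 `O=C(NCCCCCCS)c1ccn[nH]1` carries hydrogen in place of pyrazin-2-yl on an aromatic carbon. Going by the values given here, no measured step removes the group altogether, so the exchange of cyclohexyl for pyrazin-2-yl is the only guide; it was large, and it marks the substituent at this place as one that matters. Because compound 2 reaches 22 nM only with pyrazin-2-yl in place, while compound 1 with cyclohexyl stands at 241 nM, taking the group away is expected to raise the number. The step expected is a 14-fold higher number from compound 2 to compound 3 (1.13 log units; beyond the scatter). Compound 3 is therefore estimated at 300 nM in this assay, with a range from 60 nM to 1500 nM, the wide span reflecting that nothing measured here lacks a group at that position.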

Compound 3, half-maximal inhibitory concentration: 92 nM
Beside the measured number, compound 3's estimate is 3.3-fold (0.51 log units) above it; the measured number falls inside the stated range.
By their numbers in this assay, from the lowest: compound 2; then compound 3; then compound 1.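

Taking pyrazin-2-yl off this aromatic carbon gives a 4.2-fold higher number from compound 2 to compound 3 (0.62 log units; beyond the scatter), whereas putting hydrogen in place of cyclohexyl gives a 2.6-fold lower number from compound 1 to compound 3 (0.42 log units; beyond the scatter), so in this assay the unsubstituted compound falls in the middle of the three. Among the compounds shown here, the earlier pair showed only that the two groups differ; with hydrogen as the reference, a group at this place can now be seen to go with either a lower or a higher number, pyrazin-2-yl with the lower and cyclohexyl with the higher, and the core with its thiol chain needs neither group for compound 3 to reach 92 nM. Nothing available here accounts for either direction.

What the compounds shown leave open is whether phenyl or pyridin-2-yl would stay with pyrazin-2-yl on the lower side of hydrogen, or whether methyl would follow cyclohexyl to the higher side. For the compounds shown here, they also leave open where an amine or a carboxylic acid on this carbon would fall, and with only two groups set against hydrogen, no wider rule for this position can yet be drawn.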